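The compounds below may be only part of what the source reports. "The series", "measured", "known", "first", "only" and "open" are said of these compounds alone.

Compound 1 `CCOc1cc(C(=O)Nc2nn[nH]n2)nc(-c2ccc(C)cc2)c1` gives 26% in a functional assay on the whole organism for inhibition, with Rattus norvegicus as the target, at a dose of 0.3 mg/kg by the oral route; a higher number here means a stronger effect of the compound at the dose given, a lower number a weaker effect.
Compound 2 `CCOc1cc(C(=O)Nc2nn[nH]n2)nc(-c2ccc(N)cc2)c1` gives 19%.
Compound 3 `CNc1ccc(-c2cccc(C(=O)Nc3nn[nH]n3)n2)cc1` gives 29%.

Compound 2 stands lowest of these three numbers, but not by much: compound 1 is its nearest neighbour, the step of a number 7 percentage points lower from compound 1 to compound 2 (within the scatter) lying within the scatter, and compound 3, the furthest, shows a value that also sits within the scatter of compound 2. On the numbers shown, the three compounds are indistinguishable.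

Compound 4 `CC(C)c1cc(C(=O)Nc2nn[nH]n2)nc(-c2ccc(N)cc2)c1` differs from compound 2 by isopropyl in place of ethoxy on an aromatic carbon. Within the data shown here, no measured step bears directly on this change; the only measured step, a number 7 percentage points lower from compound 1 to compound 2 (within the scatter), concerns a different place on the shared core and was itself within the scatter. There is therefore no evidence that a small change on this core moves the read-out, and a step of no size beyond the scatter is expected in this assay. Compound 4 is estimated at 20%, with a range from 5% to 38%. This estimate for compound 4 means an expected step of a number 1 percentage points higher from compound 2 to compound 4 (within the scatter).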

Compound 4, a percentage reported as inhibition, in the whole organism at one dose (the size of the read-out at that dose, not a potency): 22%
The estimate for compound 4 lay 2 percentage points below the measured number, and the stated range covers the measured number.
By their numbers in this assay, from the lowest: compounds 2, 4, 1 and 3 (each within the scatter of the next).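

Among these compounds, compound 2 and compound 4 give the first direct reading at this position, opposite the ring nitrogen, and in this assay the change from ethoxy to isopropyl shows a number 3 percentage points higher from compound 2 to compound 4 (within the scatter). The exchange removes the oxygen and the hydrogen-bond acceptor of the ethoxy group while keeping the same count of heavy atoms, yet at this single oral dose the read-out does not separate the two compounds. Nothing available explains this outcome or bears on it.

Going by these compounds, what an amine, a carboxylic acid or a longer alkyl chain at this position would do to the read-out stays open. On these data alone, it is also open whether isopropyl and ethoxy would remain within the scatter of each other with the 4-aminophenyl group replaced, or at another dose.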